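Working notes: nitro in place of methyl, compound 3

The source may hold more compounds than are shown below. What is called first, only, known or untested is meant among the compounds shown, and "the series" means these compounds.

Measured in a functional assay on HCT-116 cells (Homo sapiens) for cytotoxicity, read by MTT assay, with a stated time of 72 h; a higher number here means a weaker inhibitor, a lower number a stronger inhibitor:
- Compound 1 `O=C1C=CCC/C1=C\C(Br)=C\c1ccccc1`: > 10000 nM (a limit)
- Compound 2 `Cc1ccc(/C=C/C=C2\CCC=CC2=O)cc1`: 7200 nM

Going by the values given here, compound 2, at 7200 nM, carries the only actual number so far. The next compound is compound 3 `O=C1C=CCC/C1=C\C=C\c1ccc([N+](=O)[O-])cc1`, with nitro in place of methyl on an aromatic carbon, para to a large group: nitro in place of methyl on an aromatic carbon. Among the compounds with values here, no measured step is available to scale this change, so no shift beyond the scatter is expected in this assay, in either direction. The expected change is a 1.2-fold lower number from compound 2 to compound 3 (0.08 log units; within the scatter). The estimated value for compound 3 is 6000 nM, with an expected range from 2000 nM to 12000 nM.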

Compound 3, half-maximal inhibitory concentration: 5000 nM
Compound 3: middle estimate off by 1.2-fold (0.08 log units), on the high side; the measured number falls inside the stated range.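

In this assay, nitro in place of methyl on an aromatic carbon, para to a large group, gives a 1.4-fold lower number from compound 2 to compound 3 (0.16 log units; within the scatter) and so no shift beyond the scatter at this position. Going by these compounds alone, this is the first measured step, and it shows that methyl and nitro cannot be told apart here despite the larger group entering. Compound 1 stays outside this comparison, as its reading is a limit: the limit of > 10000 nM in this assay, at which 1 of the 3 values shown sits.

As far as these compounds go, whether an amine or a carboxylic acid at this position would move the number beyond the scatter remains open.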